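This account rests on a few compounds, and the source may have more. Where it says the series, first, only, none or still open, it means among the compounds named here.

Working notes on the series. Of the compounds shown here, two have been measured so far: compound 1 `O=C1[C@@H](NS(=O)(=O)c2cc3c(Cl)nccc3s2)CCN1CCNc1ccncc1` and compound 2 `Cc1c(S(=O)(=O)N[C@H]2CCN(Cc3cc4c[nH]ccc-4n3)C2=O)sc2ccc(Cl)cc12`. In an assay on isolated protein for inhibition of coagulation factor X (Oryctolagus cuniculus), tested at 1 uM (on this read-out higher numbers stand for more inhibition at the one concentration tested (going by the name of the read-out) and lower numbers for less inhibition), compound 1 gives 39%, and in the same assay compound 2 gives 37%. Compound 2 stands lowest of the two numbers, with compound 1 nearest, but the gap between them lies within the scatter, so the two read as the same.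

Compound 3 `Cc1c(S(=O)(=O)N[C@H]2CCN(Cc3cc4cc[nH]cc-4n3)C2=O)sc2ccc(Cl)cc12` has not yet been measured in this assay. It differs from compound 2 in one place: a group of 9 heavy atoms (7 carbon, 2 nitrogen; one five-membered aromatic ring with 1 hetero atom, one six-membered aromatic ring with 1 hetero atom) in place of a group of 9 heavy atoms (7 carbon, 2 nitrogen; one five-membered aromatic ring with 1 hetero atom, one six-membered aromatic ring with 1 hetero atom), on a saturated chain carbon bound to an amide-type nitrogen in a ring. The two structures hold the same atoms, joined differently.

Among the measured compounds shown here, no step between measured compounds covers a change of this kind, so nothing in the data points to a direction. The expected step from compound 2 to compound 3 in this assay is no change at the digits printed from compound 2 to compound 3 (within the scatter), that is none beyond the scatter. On that basis compound 3 is estimated at 37% in this assay. The range expected for compound 3 runs from 15% to 60%.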

Compound 3, a percentage reported as inhibition, at one concentration (the size of the read-out at that concentration, not a potency): 52%
The estimate for compound 3 lay 15 percentage points below the measured number; low and high end bracket the measured number.
By their numbers in this assay, from the lowest: compounds 2 and 1 (each within the scatter of the next); then compound 3.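

In this assay the place on a saturated chain carbon bound to an amide-type nitrogen in a ring responds to how the group's atoms are joined, not only to which atoms it holds: the swap gives a number 15 percentage points higher from compound 2 to compound 3 (beyond the scatter), although both groups have the same heavy atoms, the same ring types, the same hydrogen-bond donor and acceptor counts and no net charge. Among the compounds shown here, compound 1 and compound 2 differ in more than one place, so they could not isolate this position, and this pair now gives the series its only single-change reading there. Nothing at hand explains why the rearranged group gives the higher number.

One step on one core leaves open whether the same rearrangement would carry over to the core of compound 1. Also open, as far as these compounds go, is how this position responds to a group of a different kind on the same chain carbon, such as a plain phenyl ring, a primary amine or a carboxylic acid.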